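A few compounds are considered here, and "the series" means these few. Any claim that something is new, unique, unknown or untested is made for them only; others in the source may bear on it.

Compound 3 `CC(O)n1cnc2c(N)nc(I)nc21` stands at a limit of a functional assay on SW-620 cells (Homo sapiens) for inhibition (a lower number here means a stronger inhibitor, a higher number a weaker inhibitor), where compound 3 gives > 500000 nM. Compound 2 `CC(O)n1cnc2c(Cl)nc(I)nc21` likewise reaches only a limit, as compound 2 gives > 500000 nM. Compound 1 `CC(=O)OCCOn1cnc2c(Cl)nc(N)nc21` also shows only a limit, with compound 1 giving > 500000 nM. The change of amino in place of chloro on an aromatic carbon is therefore a step that the two limits leave unreadable from compound 2 to compound 3. Compound 4 `Nc1nc(I)nc2c1ncn2OCCO` carries 2-hydroxyethoxy in place of 1-hydroxyethyl on an aromatic nitrogen. Among the measured compounds shown here, no measured step bears on this change; the only evidence is the limit of > 500000 nM in this assay, at which 3 of the 3 values shown sit, so no step beyond the scatter can be read in either direction. The step from compound 3 to compound 4 is estimated as a step that the limit leaves unreadable from compound 3 to compound 4. Compound 4 is expected to give 1000000 nM, within a range from 300000 nM to 5000000 nM.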

Compound 4, half-maximal inhibitory concentration: > 500000 nM
Compound 4: a limit, no number; the forecaster's own chance of this, stated with the estimate: 85%; the middle value is on the limit's open side.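

Among the compounds shown here, compound 4 reaches only a limit in this assay, > 500000 nM, so no step from compound 3 to compound 4 can be read. The compounds shown leave open how strongly any of them inhibits, and what each change does: the limit of > 500000 nM in this assay, at which 4 of the 4 values shown sit.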